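Moving a methoxy group on an aryl imine: expected cytotoxicity

The compounds below may be only part of what the source reports. "The series", "measured", "known", "first", "only" and "open" are said of these compounds alone.

Measured compounds:
- Compound 1, `Cc1c(/N=C/c2cccc(O)c2)c(=O)n(-c2ccccc2)n1C`: 617000000 nM
- Compound 2, `COc1cccc(/C=N/c2c(C)n(C)n(-c3ccccc3)c2=O)c1`: 933000000 nM

Both compounds were tested in a functional assay on HCT-116 cells (Homo sapiens) for cytotoxicity, read by MTT assay, with a stated time of 72 h; a lower number here means a stronger inhibitor, a higher number a weaker inhibitor. Among the compounds with values here, compound 2 gives 933000000 nM, and compound 1 gives 617000000 nM; the only measured step, a 1.5-fold higher number from compound 1 to compound 2 (0.18 log units; within the scatter), lies within the scatter, so the two values cannot be told apart.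

Compound 3, `COc1ccccc1/C=N/c1c(C)n(C)n(-c2ccccc2)c1=O`, is not yet measured. Its change from compound 2 is 2-methoxyphenyl in place of 3-methoxyphenyl on a carbon with a double bond to nitrogen. Within the data shown here, no measured step concerns where the methoxy group sits on the ring; the one known step only swaps methyl for hydrogen on the oxygen and does not bear on this change. With nothing to point either way, the expectation is a step of no change at the digits printed from compound 2 to compound 3 (within the scatter), that is, none beyond the scatter. Compound 3 is therefore estimated at 933000000 nM, with a range from 300000000 nM to 2800000000 nM.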

Compound 3, half-maximal inhibitory concentration: 324000000 nM
For compound 3 the middle estimate is 2.9-fold (0.46 log units) above the measured one; low and high end bracket the measured number.
By their numbers in this assay, from the lowest: compounds 3, 1 and 2 (each within the scatter of the next, the first and the last beyond it).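

In this assay, within the data shown here, the place of the methoxy group on the ring does show up in the number: 2-methoxyphenyl in place of 3-methoxyphenyl gives a 2.9-fold lower number from compound 2 to compound 3 (0.46 log units; beyond the scatter) as the first step to pass the scatter, though only modestly. Set against the 3-hydroxyphenyl of compound 1, the same 2-methoxyphenyl group gives a 1.9-fold lower number from compound 1 to compound 3 (0.28 log units; within the scatter) and so cannot be told apart from it. Nothing available explains why the two methoxy compounds differ.

Among these compounds, open is whether 4-methoxyphenyl would continue this trend or break it, since only two places on the ring appear here. Going by these compounds, it is also open whether a group of another kind on the ring, such as an amine or a carboxylic acid, would change the number more than moving the methoxy group does.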